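A few compounds are considered here, and "the series" means these few. Any claim that something is new, unique, unknown or untested is made for them only; others in the source may bear on it.

In a functional assay on HCT-116 cells (Homo sapiens) for inhibition, read by luminescence and resazurin assay, with a stated time of 3 days (on this read-out lower numbers stand for stronger inhibition and higher numbers for weaker inhibition), compound 1 `C=CCNc1nc(NCc2ccc(C(=O)Nc3ccc(F)cc3)cc2)c2cc(C)ccc2n1` gives 13000 nM, the highest of the three numbers recorded. Compound 2 `Cc1ccc2nc(N3CCNC(C)C3)nc(NCc3ccc(C(=O)NC4CCN(Cc5ccc(F)cc5)CC4)cc3)c2c1` gives 2000 nM in this assay, and compound 3 `CCCNc1nc(NCc2ccc(C(=O)Nc3ccc(F)cc3)cc2)c2cc(C)ccc2n1` gives 1200 nM. Compound 1 thus stands nearer to compound 2 and furthest from compound 3, with both gaps beyond the scatter. Among the measured compounds shown here, the only single change among the measured compounds is an 11-fold lower number from compound 1 to compound 3 (1.03 log units; beyond the scatter), which concerns the chain on the amine.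

Compound 4 `C=CCNc1nc(NCc2ccc(C(=O)Nc3ccc(F)cc3)cc2)c2ccccc2n1` differs from compound 1 by hydrogen in place of methyl on an aromatic carbon. For the measured compounds named here, no measured pair shows this change on the fused ring system, and the one measured step, an 11-fold lower number from compound 1 to compound 3 (1.03 log units; beyond the scatter), sits elsewhere in the molecule and offers no guide to it. Removing one methyl leaves the rest of compound 1 untouched, so the expectation for compound 4 is a step no larger than the usual scatter in this assay, in no fixed direction. The estimate for compound 4 is accordingly 15000 nM, within a range from 5000 nM to 45000 nM. For compound 4 the expected step is a 1.2-fold higher number from compound 1 to compound 4 (0.06 log units; within the scatter), and the measurement will show whether that holds.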

Compound 4, half-maximal inhibitory concentration: 14000 nM
Beside the measured number, compound 4's estimate is 1.1-fold (0.03 log units) above it; the measured number falls inside the stated range.
By their numbers in this assay, from the lowest: compounds 3 and 2 (each within the scatter of the next); then compounds 1 and 4 (each within the scatter of the next).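

In this assay, among the compounds shown here, the step for hydrogen in place of methyl on an aromatic carbon is a 1.1-fold higher number from compound 1 to compound 4 (0.03 log units; within the scatter), the first reading of any change at this position. With the chain on the amine of compound 1 in place, the methyl on this six-membered aromatic ring of carbon only, part of a fused or bridged system of two rings, can therefore be removed without a change that stands out from the scatter, whereas the change on the chain gives an 11-fold lower number from compound 1 to compound 3 (1.03 log units; beyond the scatter). No measured evidence bears on why the methyl makes so little difference here.

Only hydrogen and methyl are shown at this carbon, so it remains open what a chlorine, a methoxy group or a trifluoromethyl group would do there. As far as these compounds go, it is also open whether removing the methyl from compound 3, with its saturated chain on the amine, would give an equally small step, since this single pair cannot show whether the result carries over to other compounds of the set.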